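A few compounds are considered here, and "the series" means these few. Any claim that something is new, unique, unknown or untested is made for them only; others in the source may bear on it.

Measured compounds in a functional assay (blood) for inhibition, with Homo sapiens as the target; on this read-out higher numbers stand for weaker inhibition and lower numbers for stronger inhibition:
Compound 1, `CCOC(=O)/C(=N\O)c1ccc(Sc2cc(F)cc(C3CCOCC3)c2)cc1`: 170 nM
Compound 2, `CC(C)/C(=N\O)c1ccc(Sc2cc(F)cc(C3CCOCC3)c2)cc1`: 300 nM
Compound 3, `COC(=O)C(C)(C)CO/N=C(\C)c1ccc(Sc2cc(F)cc(C3CCOCC3)c2)cc1`: 420 nM

Compound 3 gives the highest of the three numbers; the gap to compound 2 lies within the scatter, while the gap to compound 1 lies beyond it. Compound 4, `CC(=O)O/N=C(\C)c1ccc(Sc2cc(F)cc(C3CCOCC3)c2)cc1`, differs from compound 3 by acetyl in place of 2-(methoxycarbonyl)-2-methylpropyl on an oxygen. For the measured compounds named here, the only measured step, a 1.8-fold higher number from compound 1 to compound 2 (0.25 log units; within the scatter), concerns the carbon with a double bond to nitrogen and not the oxygen, so no measured step bears directly on this change, and that step itself stayed within the scatter. The step of a 1.1-fold lower number from compound 3 to compound 4 (0.02 log units; within the scatter) is therefore expected to remain within the scatter, in no clear direction. In this assay compound 4 is estimated at 400 nM, with a range from 150 nM to 1100 nM.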

Compound 4, half-maximal inhibitory concentration: 50 nM
Compound 4: the middle estimate sits 8.0-fold (0.90 log units) above what was measured; measured number outside the range, below it.
By their numbers in this assay, from the lowest: compound 4; then compounds 1, 2 and 3 (each within the scatter of the next, the first and the last beyond it).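

In this assay, for the compounds shown here, the change on the oxygen whose other neighbour is the double-bonded nitrogen, acetyl in place of 2-(methoxycarbonyl)-2-methylpropyl, gives an 8.4-fold lower number from compound 3 to compound 4 (0.92 log units; beyond the scatter) and shows that this position can move the number beyond the scatter, which the one earlier step did not. Compound 4 also stands apart from the other two compounds, with a 6.0-fold lower number from compound 2 to compound 4 (0.78 log units; beyond the scatter) and a 3.4-fold lower number from compound 1 to compound 4 (0.53 log units; beyond the scatter) in the same direction, making it the most potent of the four. No evidence on the cause is at hand.

The compounds shown leave open whether propanoyl, benzoyl or a plain methyl on this oxygen would behave like acetyl. They also leave open whether acetyl on this oxygen would give a similar step with the ethoxycarbonyl or isopropyl group on the carbon with a double bond to nitrogen.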